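Chloroethenyl for hydroxypropynyl on a deoxyuridine: expected cytotoxicity

The source may hold more compounds than are shown below. What is called first, only, known or untested is meant among the compounds shown, and "the series" means these compounds.

Measured compounds:
compound 1, `O=C1O/C(=C\Cn2cc(Cl)c(=O)[nH]c2=O)C(OCc2ccccc2)=C1OCc1ccccc1`, gives 12200 nM in an ADME assay on L1210/0 cells (Mus musculus) for cytotoxicity, with a stated time of 48 h; on this read-out lower numbers stand for stronger inhibition and higher numbers for weaker inhibition
compound 2, `O=c1[nH]c(=O)n([C@H]2C[C@H](O)[C@@H](CO)O2)cc1C#CCO`, gives > 200000 nM in this assay

Compound 2 stands at the limit of > 200000 nM in this assay, at which 1 of the 2 values shown sits; its reading is a limit of the measurement, not a number. Compound 3, `O=c1[nH]c(=O)n([C@H]2C[C@H](O)[C@@H](CO)O2)cc1/C=C/Cl`, differs from compound 2 by 2-chloroethenyl in place of 3-hydroxyprop-1-yn-1-yl on an aromatic carbon. Among the compounds with values here, no measured pair covers this change, so in this assay no shift beyond the usual scatter is expected, and a limit again seems likely. The estimated step of an at least 1.3-fold lower number from compound 2 to compound 3 (0.12 log units; that floor lies within the scatter) is therefore small. Compound 3 is expected near 150000 nM, within 30000 nM to 400000 nM.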

Compound 3, half-maximal inhibitory concentration: > 200000 nM
Compound 3: only a limit was reported; the forecaster's own chance of this, stated with the estimate: 60%; middle value at least 1.3-fold (0.12 log units) away from the limit.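

Compound 2 and compound 3 both give only a limit, not a number, in this assay, so no step between them can be read: the limit of > 200000 nM in this assay, at which 2 of the 3 values shown sit.

As far as these compounds go, whether 2-chloroethenyl in place of 3-hydroxyprop-1-yn-1-yl changes cytotoxicity at all remains open.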